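Bromo for hydrogen on two cores: stability notes

A few compounds are considered here, and "the series" means these few. Any claim that something is new, unique, unknown or untested is made for them only; others in the source may bear on it.

Measured in an ADME assay on microsomes from liver (Homo sapiens) for metabolic stability; a higher number here means that the compound lasts longer, a lower number that the compound disappears faster:
compound 1 `CCCNC(=O)C1CCN(C(=O)c2cccn2Cc2ccc(OC)cc2)CC1` gives 0.112 h
compound 2 `CCCNC(=O)C1CCN(C(=O)c2cc3cc(Br)ccc3n2Cc2ccc(OC)cc2)CC1` gives 0.0657 h
compound 3 `CCCNC(=O)C1CCN(C(=O)c2cc3ccccc3n2Cc2ccc(OC)cc2)CC1` gives 0.0443 h

Compound 1 and compound 2 lie within the scatter of each other in this assay; compound 3 lies beyond it from compound 1. The difference between the cores of compound 1 and compound 3 is not broken down here. On the core of compound 3, bromo in place of hydrogen on an aromatic carbon gave a 1.5-fold higher number from compound 3 to compound 2 (0.17 log units; within the scatter). Compound 4 `CCCNC(=O)C1CCN(C(=O)c2ccc(Br)n2Cc2ccc(OC)cc2)CC1` carries the same kind of change on the core of compound 1: bromo in place of hydrogen on an aromatic carbon. The place is not the same: in compound 2 the bromo sits on a six-membered aromatic ring of carbon only, part of a fused or bridged system of two rings, meta to a fused ring and para to a fused ring; in compound 4 it sits on a five-membered aromatic ring with 1 nitrogen, next to the ring nitrogen and next to the ring atom that bears a 4-methoxybenzyl group. In this assay compound 4 is expected to show a 1.3-fold higher number from compound 1 to compound 4 (0.10 log units; within the scatter), a small step, because a 1.5-fold higher number from compound 3 to compound 2 (0.17 log units; within the scatter) stayed within the scatter. Compound 4 is estimated at 0.14 h, between 0.07 h and 0.28 h.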

Compound 4, half-life: 0.122 h
For compound 4 the middle estimate is 1.1-fold (0.06 log units) above the measured one; the range from low to high includes it.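

In this assay, bromo in place of hydrogen on an aromatic carbon gave a 1.1-fold higher number from compound 1 to compound 4 (0.04 log units; within the scatter), and the step agrees with the one on the other core: the same change on two cores in this assay, a 1.5-fold higher number (0.17 log units; within the scatter) from compound 3 to compound 2 and a 1.1-fold higher number (0.04 log units; within the scatter) from compound 1 to compound 4, 1.4-fold (0.13 log units) apart, within the scatter of two such steps.
On these two cores the change therefore carries over as a small step, even though the bromo does not occupy the same place in compound 2 and compound 4.
This does not show that bromo lengthens the half-life, since neither step leaves the scatter, and two pairs cannot establish a rule for the series.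

Still open, as far as these compounds go, is whether an amine or a nitrile on the same aromatic carbon would carry across these cores in the same way. Also open, from the compounds shown here alone, is how a carboxylic acid or a longer chain in place of the 4-methoxybenzyl group would behave.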